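Adding a Second Bromo Group to a Dinitro Diaryl Ether

The source may report more compounds than this note shows. Statements on the series, on what has been measured and on what is new or still open speak of the compounds shown alone.

Measured compounds:
compound 1 `O=[N+]([O-])c1cc(C(F)(F)F)cc([N+](=O)[O-])c1Oc1ccccc1/C=N/OCc1ccccc1Cl` with 1100 nM in a functional assay on MCF7 cells (Homo sapiens) for antiproliferative activity, read by MTT assay, with a stated time of 48 h; a lower number here means a stronger inhibitor, a higher number a weaker inhibitor
compound 2 `O=[N+]([O-])c1cc(C(F)(F)F)cc([N+](=O)[O-])c1Oc1ccc(Br)cc1/C=N\OCc1ccccc1` with 1150 nM in this assay
compound 3 `O=[N+]([O-])c1cc(C(F)(F)F)cc([N+](=O)[O-])c1Oc1ccc(Br)cc1/C=N/OCc1ccccc1Cl` with 2840 nM in this assay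

Compound 1 and compound 3 differ in one place:

bromo in place of hydrogen on an aromatic carbon

This change gave a 2.6-fold higher number from compound 1 to compound 3 (0.41 log units; beyond the scatter). Compound 2 and compound 3 differ by a 2.5-fold higher number from compound 2 to compound 3 (0.39 log units; beyond the scatter). The difference between the cores of compound 1 and compound 2 is not broken down here.

Compound 4 `O=[N+]([O-])c1cc(C(F)(F)F)cc([N+](=O)[O-])c1Oc1c(Br)cc(Br)cc1/C=N\OCc1ccccc1` has not yet been measured in this assay. It differs from compound 2 as follows:

bromo in place of hydrogen on an aromatic carbon

This is the same kind of change as from compound 1 to compound 3, but the surroundings differ: here the entering bromo sits ortho to a large group and meta to a bromo group, whereas in compound 3 it sits meta and para to large groups. Resting on compound 1 to compound 3, the expected step is a 2.3-fold higher number from compound 2 to compound 4 (0.35 log units; beyond the scatter). The estimate for compound 4 is 2600 nM, between 1200 nM and 5600 nM.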

Compound 4, half-maximal inhibitory concentration: 1830 nM
The estimate for compound 4 lay 1.4-fold (0.15 log units) above the measured number; low and high end bracket the measured number.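

In this assay, placing a bromo on the ring of compound 2 gave a 1.6-fold higher number from compound 2 to compound 4 (0.20 log units; within the scatter), so on this core the effect of the change cannot be told apart from the ordinary spread of repeated measurements. Set beside the earlier step, the two results do not differ by more than two such steps normally would: the same change on two cores in this assay, a 2.6-fold higher number (0.41 log units; beyond the scatter) from compound 1 to compound 3 and a 1.6-fold higher number (0.20 log units; within the scatter) from compound 2 to compound 4, 1.6-fold (0.21 log units) apart, within the scatter of two such steps. The change therefore carries over between these two cores as far as this assay can resolve, but two pairs, with the bromo in different surroundings, do not show that it would behave alike on other cores in the series.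

The compounds shown leave open what a different group at this place, such as a methoxy group or an amine, would do.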